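Aryl Ether for Phenyl on a Shared Core: Permeability Outlook

The source may report more compounds than this note shows. Statements on the series, on what has been measured and on what is new or still open speak of the compounds shown alone.

Compound 1, `COc1cccc(Oc2ccc3c(NCCCNCc4cc(F)ccc4OC)ccnc3c2)c1`: 317 10^-6 cm/s in an ADME assay for permeability, using PAMPA, with a stated time of 30 min, at pH 7.4; a higher number here means that the compound crosses the layer faster, a lower number that the compound crosses the layer more slowly
Compound 2, `COc1ccc(F)cc1CNCCCNc1ccnc2cc(-c3ccccc3)ccc12`: 237 10^-6 cm/s in this assay

Compound 2 stands beside compound 1: the step of a 1.3-fold lower number from compound 1 to compound 2 (0.13 log units; within the scatter) lies within the scatter, so neither number is set apart from the other. Compound 3, `COc1ccc(F)cc1CNCCCNc1ccnc2cc(Oc3ccc(F)cc3)ccc12`, differs from compound 2 by 4-fluorophenoxy in place of phenyl on an aromatic carbon. Going by the values given here, the only step that bears on this change is a 1.3-fold lower number from compound 1 to compound 2 (0.13 log units; within the scatter), where phenyl replaced 3-methoxyphenoxy; the present change runs the opposite way. Compound 3 is therefore expected to show a 1.2-fold higher number from compound 2 to compound 3 (0.09 log units; within the scatter), no step beyond the scatter. The estimate for compound 3 in this assay is 290 10^-6 cm/s, ranging from 180 10^-6 cm/s to 450 10^-6 cm/s.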

Compound 3, apparent permeability: 317 10^-6 cm/s
Compound 3: the middle estimate sits 1.1-fold (0.04 log units) below what was measured, within the range that was stated.
By their numbers in this assay, from the lowest: compounds 2, 1 and 3 (each within the scatter of the next).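

With 4-fluorophenoxy set directly against phenyl on this aromatic carbon, this assay gives a 1.3-fold higher number from compound 2 to compound 3 (0.13 log units; within the scatter) for the change. Changing only the ring on the ether oxygen, with 4-fluorophenyl in place of 3-methoxyphenyl, gives no change at the digits printed from compound 1 to compound 3 (within the scatter), so all three groups at this position read alike within the scatter. No available evidence bears on these readings. The compounds shown leave open whether an amine or a carboxylic acid on this aromatic carbon would give a step beyond the scatter.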